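Dichloro for dimethyl on the piperazine aryl of compound 1

The compounds below may be only part of what the source reports. "The series", "measured", "known", "first", "only" and "open" are said of these compounds alone.

Among the measured compounds shown here, compound 1 `Cc1cccc(N2CCN(CCCNc3nc(NCc4ccco4)c4ccccc4n3)CC2)c1C` is the one member of this series with a number in hand. In a functional assay on MCF7 cells (Homo sapiens) for cytotoxicity, read by MTT assay, with a stated time of 2 days, tested at 10 uM (a lower number here means less inhibition, a higher number more inhibition at the concentration tested (going by the name of the read-out)), compound 1 gives 95.9%, an inhibition that sits close to the top of the scale the read-out allows. Two further analogues share the same furanylmethyl-amine and piperazine-linked arrangement: compound 2 `Fc1ccc2nc(NCCCCN3CCN(c4cccc(Cl)c4Cl)CC3)nc(NCc3ccco3)c2c1` carries a fluorine on the core and a dichlorophenyl on the piperazine, and in this assay compound 2 has "not determined" (no result reported). Compound 3 `Cc1cccc(N2CCN(CCCNc3nc(NCc4ccco4)c4cc(F)ccc4n3)CC2)c1C` keeps the dimethylphenyl of compound 1 and adds the same core fluorine, and in this assay compound 3 likewise has "not determined" (no result reported). So no step between measured compounds can be drawn, and compound 1 stands alone.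

Compound 4 `Clc1cccc(N2CCN(CCCNc3nc(NCc4ccco4)c4ccccc4n3)CC2)c1Cl` is the unmeasured analogue: 2,3-dichlorophenyl in place of 2,3-dimethylphenyl on an amine nitrogen in a ring. With compound 1 already near the ceiling, little room remains for an upward step, and a change of this kind, which keeps heavy-atom count, donor and acceptor count and charge unchanged, is expected to leave the read-out within or only slightly below the scatter. The step of a number 5.9 percentage points lower from compound 1 to compound 4 (within the scatter) is expected to be small and, if anything, downward. Compound 4 is therefore estimated at 90%, with a range from 70% to 99%.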

Compound 4, a percentage reported as inhibition, at one concentration (the size of the read-out at that concentration, not a potency): 95.9%
The estimate for compound 4 lay 5.9 percentage points below the measured number, within the range that was stated.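

In this assay, among the compounds shown here, 2,3-dichlorophenyl in place of 2,3-dimethylphenyl on an amine nitrogen in a ring gives no change at the digits printed from compound 1 to compound 4 (within the scatter), which makes this the one readable step. At this position, then, the read-out stays close to the top of its scale with either group, and the exchange of the two methyl groups for two chlorine atoms costs nothing that this read-out can detect. As the read-out gives the size of the inhibition at a single concentration and not a potency, this shows that the two compounds are alike at that concentration only, and no measurement shown here bears on why the two groups read alike.

From the compounds shown here alone, whether compound 1 and compound 4 would still read alike at lower concentrations, where the read-out would sit away from the top of its scale, stays open. Also open, going by these compounds, is whether the number stays level with groups of a different kind on the same ring nitrogen, such as an unsubstituted phenyl, a methoxyphenyl or a phenyl bearing a carboxylic acid.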